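The source may hold more compounds than are shown below. What is called first, only, known or untested is meant among the compounds shown, and "the series" means these compounds.

Among the compounds with values here, compound 2 `Clc1cccc(-c2cc(-c3ccc(Cl)o3)cc(-c3cccs3)n2)c1` gives 19800 nM in a functional assay on K562 cells (Homo sapiens) for cytotoxicity, in the presence of a further agent that is not named here (on this read-out higher numbers stand for weaker inhibition and lower numbers for stronger inhibition), the lowest of the two numbers measured so far, although compound 1 `Clc1ccc(-c2cc(-c3cccnc3)nc(-c3cccs3)c2)o1`, at 22300 nM, lies within the scatter of it; the step of a 1.1-fold lower number from compound 1 to compound 2 (0.05 log units; within the scatter) was small. Compound 3 `Cc1ccc(-c2cc(-c3ccc(Cl)o3)cc(-c3cccs3)n2)cc1` differs from compound 2 by 4-methylphenyl in place of 3-chlorophenyl on an aromatic carbon. Within the data shown here, the only step measured, from compound 1 to compound 2, swapped one ring group for another at this same place and stayed within the scatter, so for compound 3 the step of a 1.0-fold higher number from compound 2 to compound 3 (0.00 log units; within the scatter) is expected to be small. Compound 3 is therefore expected to give 20000 nM, within a range from 8000 nM to 50000 nM.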

Compound 3, half-maximal inhibitory concentration: 21500 nM
Beside the measured number, compound 3's estimate is 1.1-fold (0.03 log units) below it; measured number inside the range.
By their numbers in this assay, from the lowest: compounds 2, 3 and 1 (each within the scatter of the next).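

Replacing 3-chlorophenyl with 4-methylphenyl gives a 1.1-fold higher number from compound 2 to compound 3 (0.04 log units; within the scatter), and replacing pyridin-3-yl with 4-methylphenyl gives a 1.0-fold lower number from compound 1 to compound 3 (0.02 log units; within the scatter). In this assay, all three aromatic rings tested at this place, next to the ring nitrogen, therefore give numbers within the scatter of one another, whether the ring carries chlorine, carries methyl or contains nitrogen. No measurement here explains this lack of separation.

Going by these compounds, it remains open whether an amine, a carboxylic acid or a longer chain at this place would shift the number beyond the scatter. Changes to the 5-chlorofuran-2-yl or thiophen-2-yl groups also remain open.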